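A few compounds are considered here, and "the series" means these few. Any claim that something is new, unique, unknown or untested is made for them only; others in the source may bear on it.

Compound 1 `CCCc1nc(N2CCN(c3ccccc3OC)CC2)c2cc(OC)c(OC)cc2n1`: > 80000 nM
Compound 2 `COc1cc2nc(C3CCCC3)nc(N3CCN(c4ccccc4OC)CC3)c2cc1OC`: > 80000 nM
Compound 3 `COc1ccc2nc(C3CCC3)nc(N3CCN(c4ccccc4OC)CC3)c2c1`: > 80000 nM

In an in vitro assay on U2OS cells for agonist activity at neurotensin receptor type 2 (Homo sapiens), read by reporter gene assay and beta-arrestin recruitment (on this read-out higher numbers stand for an effect only at larger amounts of compound and lower numbers for an effect already at smaller amounts), compound 1 gives only a limit, > 80000 nM. In this assay compound 2 likewise gives only a limit, > 80000 nM. Among the measured compounds shown here, the one measured step, a step that the two limits leave unreadable from compound 1 to compound 2, is left unreadable by these two limits. Compound 3 also stands at a limit in this assay, > 80000 nM, so that every value shown sits at the same limit, as the limit of > 80000 nM in this assay, at which 3 of the 3 values shown sit, states, and nothing in the set separates one compound from another.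

Compound 4 `COc1ccccc1N1CCN(c2nc(C3CCC3)nc3ccccc23)CC1` differs from compound 3 by hydrogen in place of methoxy on an aromatic carbon. No measured step touches this change; the only step shown concerns a different group at a different position, and it is itself unreadable. With compound 3 at the limit > 80000 nM, the expected step that the limit leaves unreadable from compound 3 to compound 4 cannot be read off, and the most that can be said is that compound 4 is expected to remain near the same limit. Compound 4 is therefore estimated at 100000 nM in this assay, with a range from 20000 nM to 500000 nM.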

Compound 4, half-maximal effective concentration: > 80000 nM
Compound 4 was reported as a limit (the forecaster's own chance of this, stated with the estimate: 85%); the middle value is on the limit's open side.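

Compound 3 and compound 4 each give only a limit in this assay, so no step can be read for hydrogen in place of methoxy, and every value shown is the same limit: the limit of > 80000 nM in this assay, at which 4 of the 4 values shown sit.

The compounds shown leave open whether any of them differs from another in this assay, and which change would give a value rather than a limit.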